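This account rests on a few compounds, and the source may have more. Where it says the series, first, only, none or still open, it means among the compounds named here.

Working notes on a functional assay on HCT-116 cells (Homo sapiens) for cytotoxicity, with a stated time of 3 days; on this read-out lower numbers stand for stronger inhibition and higher numbers for weaker inhibition. Compound 1 `C=Cc1nc2ccccc2[se]1` carries a vinyl group on the shared core and gives > 40000 nM, which is a limit. Compound 2 `Brc1nc2ccccc2[se]1` has bromo in that place and gives > 40000 nM, which is also a limit. Going by the values given here, the one step on this core, a step that the two limits leave unreadable from compound 1 to compound 2, therefore has no readable size. Among the compounds with values here, compound 3 `C#Cc1nc(C(=O)Nc2ccc(Cl)cc2)cs1`, built on a different core, gives 15900 nM, the only value that is not a limit. Within the data shown here, it is linked to the others by no measured step.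

Compound 4 `c1ccc2[se]cnc2c1` follows from compound 2 by hydrogen in place of bromo on an aromatic carbon, with hydrogen in place of bromo on an aromatic carbon, next to the ring nitrogen and next to the ring selenium. The main guide is the limit of > 40000 nM in this assay, at which 2 of the 3 values shown sit. Among the measured compounds shown here, no measured step gives a size to carry over, so no change beyond the scatter and no direction is expected for a number no higher from compound 2 to compound 4 (the limit leaves the size open). The estimate for compound 4 is 40000 nM, with an expected range of 18000 nM to 80000 nM.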

Compound 4, half-maximal inhibitory concentration: > 40000 nM
Compound 4: only a limit was reported; the forecaster's own chance of this, stated with the estimate: 70%; the middle value sits exactly at the limit.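

Compound 4 joins compound 1 and compound 2 as a limit, and no new step among these three compounds can be read: the limit of > 40000 nM in this assay, at which 3 of the 4 values shown sit.

The compounds shown leave open whether vinyl, bromo or hydrogen on this aromatic carbon makes any difference to the read-out on the shared core.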